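Swapping the phenol of a semicarbazone for a dimethylphenol

The source may report more compounds than this note shows. Statements on the series, on what has been measured and on what is new or still open speak of the compounds shown alone.

Measured compounds:
compound 1, `COc1ccc(OC)c(/C=N/NC(=O)Nc2ccc(Oc3ccnc(-c4nncn4CCN(C)C)c3)c(F)c2)c1`, 1510 nM
compound 2, `CN(C)CCn1cnnc1-c1cc(Oc2ccc(NC(=O)N/N=C/c3cccc(O)c3)cc2F)ccn1`, 1370 nM

Both compounds share a large core and differ only in the aryl group attached to the carbon with a double bond to nitrogen. In a functional assay on MKN-45 cells (Homo sapiens) for cytotoxicity, read by MTT assay, with a stated time of 72 h (a lower number here means a stronger inhibitor, a higher number a weaker inhibitor), compound 1 gives 1510 nM, and in this assay compound 2 gives 1370 nM. For the measured compounds named here, compound 2 stands at one end of the two numbers, but its only neighbour, compound 1, lies within the scatter of it, so the two cannot be told apart.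

Compound 3, `Cc1cc(/C=N/NC(=O)Nc2ccc(Oc3ccnc(-c4nncn4CCN(C)C)c3)c(F)c2)cc(C)c1O`, has not yet been measured. It differs from compound 2 in one place: 4-hydroxy-3,5-dimethylphenyl in place of 3-hydroxyphenyl on a carbon with a double bond to nitrogen. Going by the values given here, the one step measured so far, a 1.1-fold lower number from compound 1 to compound 2 (0.04 log units; within the scatter), altered the same aryl group and produced no change beyond the scatter. On that basis a similar outcome is expected for the change to compound 3: the step of a 1.0-fold higher number from compound 2 to compound 3 (0.01 log units; within the scatter) is estimated to stay within the scatter. Compound 3 is therefore expected to give about 1400 nM in this assay, with a plausible range from 600 nM to 3500 nM.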

Compound 3, half-maximal inhibitory concentration: 1510 nM
For compound 3 the middle estimate is 1.1-fold (0.03 log units) below the measured one; the measured number falls inside the stated range.
By their numbers in this assay, from the lowest: compounds 2, 1 and 3 (each within the scatter of the next).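

In this assay the 4-hydroxy-3,5-dimethylphenyl group, with 9 heavy atoms against 7 in 3-hydroxyphenyl, gives a 1.1-fold higher number from compound 2 to compound 3 (0.04 log units; within the scatter), so a larger aryl group on the carbon with a double bond to nitrogen leaves the number indistinguishable from that of compound 2. Set against the 2,5-dimethoxyphenyl group, the same change gives no change at the digits printed from compound 1 to compound 3 (within the scatter), which means that three differently substituted aryl groups at this one position, carrying a hydroxyl, two methoxy groups, or a hydroxyl with two methyl groups, now cannot be told apart in this cell assay. Nothing available explains why these three aryl groups read alike.

On these data alone, all three groups are phenyl rings that carry oxygen, so it remains open whether this position would stay just as flat with a ring bearing an amine or a carboxylic acid, or with a longer chain on the ring. A plain unsubstituted phenyl ring at this position would also show whether the oxygen-bearing groups contribute anything to the number at all.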